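The compounds below may be only part of what the source reports. "The series", "measured", "known", "first", "only" and "open" are said of these compounds alone.

Measured compounds: compound 1 `COc1ccc(-n2nc(C(=O)Nc3ccc(C)cc3)nc2-c2cc(OC)c(OC)c(OC)c2)cc1`, with 38%; compound 2 `COc1ccc(-n2nc(C(=O)Nc3ccc(C(=O)O)cc3)nc2-c2cc(OC)c(OC)c(OC)c2)cc1`, with 50%.

Among the measured compounds shown here, in a functional assay on the whole organism for inhibition, with Rattus norvegicus as the target, read by paw edema, with stated times of 30 min and 1 h, at a dose of 0.28 mmol/kg by the oral route (on this read-out lower numbers stand for less inhibition and higher numbers for more inhibition at the one dose given (going by the name of the read-out)), compound 2 stands highest of the two numbers; its nearest neighbour is compound 1, which gives 38%, and the one step between them, a number 12 percentage points higher from compound 1 to compound 2 (beyond the scatter), came from carboxy in place of methyl on an aromatic carbon. Compound 3 `COc1ccc(-n2nc(C(=O)Nc3ccc(O)cc3)nc2-c2cc(OC)c(OC)c(OC)c2)cc1` differs from compound 2 as follows: hydroxy in place of carboxy on an aromatic carbon. For the measured compounds named here, only the single step from compound 1 to compound 2 bears on this, and only loosely, since the group entering here is neither methyl nor carboxy. Compound 1 and compound 2 together set the span within which compound 3 is expected to fall, and the step from compound 2 to compound 3 is expected to be small, as a number 7 percentage points lower from compound 2 to compound 3 (within the scatter), within or barely beyond the scatter. Compound 3 is therefore estimated at 43% in this assay, with a range from 28% to 58%.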

Compound 3, a percentage reported as inhibition, in the whole organism at one dose (the size of the read-out at that dose, not a potency): 36%
Compound 3: the middle estimate sits 7 percentage points above what was measured, and the stated range covers the measured number.
By their numbers in this assay, from the lowest: compounds 3 and 1 (each within the scatter of the next); then compound 2.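

In this assay, putting hydroxy in place of carboxy at this position, on an aromatic carbon para to a large group, gives a number 14 percentage points lower from compound 2 to compound 3 (beyond the scatter), so the higher number of compound 2 does not extend to hydroxy, although the counts of hydrogen-bond donors and acceptors do not change between these two groups. Hydroxy in place of methyl gives a number 2 percentage points lower from compound 1 to compound 3 (within the scatter), so of the three groups compared here, only carboxy stands apart, while methyl and hydroxy cannot be told apart. Nothing available explains why carboxy stands apart from the other two groups.

As far as these compounds go, whether an amine or a methyl ester at this position would fall with methyl and hydroxy or reach the level of carboxy remains open. From the compounds shown here alone, it is also open whether carboxy would keep its advantage on another carbon of this ring.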